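Trifluoromethyl in Place of Methyl on the Aryl Ring

The source may hold more compounds than are shown below. What is called first, only, known or untested is meant among the compounds shown, and "the series" means these compounds.

Compound 1 `Cc1[nH]cnc1CN1CCN(c2ccccc2)C1=O` gives 26.9 nM in a functional assay (Cavia porcellus) for antagonist activity at Serotonin 3 (5-HT3) receptor (Homo sapiens); on this read-out higher numbers stand for weaker inhibition and lower numbers for stronger inhibition. Compound 2 `Cc1[nH]cnc1CN1CCN(c2cccc(C#N)c2)C1=O` gives 134 nM in this assay, and compound 3 `Cc1cccc(N2CCN(Cc3nc[nH]c3C)C2=O)c1` gives 45.7 nM. Among the three numbers compound 3 stands second highest; its nearest neighbour is compound 1, with the step of a 1.7-fold higher number from compound 1 to compound 3 (0.23 log units; within the scatter) lying within the usual scatter, while the step of a 2.9-fold lower number from compound 2 to compound 3 (0.47 log units; beyond the scatter) lies beyond it. Compound 4 `Cc1[nH]cnc1CN1CCN(c2cccc(C(F)(F)F)c2)C1=O` carries trifluoromethyl in place of methyl on an aromatic carbon, the new group sitting on an aromatic carbon of a six-membered aromatic ring of carbon only, meta to a large group. Going by the values given here, two measured steps bear on this change. The step of a 5.0-fold higher number from compound 1 to compound 2 (0.70 log units; beyond the scatter) shows how far a cyano group moves the number upward from the unsubstituted ring, and the step of a 2.9-fold lower number from compound 2 to compound 3 (0.47 log units; beyond the scatter) shows that methyl brings the number a good way back. Among the compounds with values here, no measured step involves a trifluoromethyl group, so the expectation can only be framed by the two groups already seen at that position. Compound 4 is expected to land between the methyl and cyano cases, a step of a 1.8-fold higher number from compound 3 to compound 4 (0.24 log units; within the scatter) in this assay that would be modest but probably beyond the scatter. The estimate for compound 4 is 80 nM, with a range from 30 nM to 220 nM.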

Compound 4, antagonist equilibrium constant: 68.5 nM
Compound 4: middle estimate off by 1.2-fold (0.07 log units), on the high side, and the stated range covers the measured number.
By their numbers in this assay, from the lowest: compounds 1, 3, 4 and 2 (each within the scatter of the next, the first and the last beyond it).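

In this assay, trifluoromethyl in place of methyl on this aromatic carbon gives a 1.5-fold higher number from compound 3 to compound 4 (0.18 log units; within the scatter), and trifluoromethyl in place of cyano gives a 2.0-fold lower number from compound 2 to compound 4 (0.29 log units; within the scatter). The new group therefore cannot be told apart from either of the two groups already seen at this position, even though those two differ from each other by more than the scatter. The step from the unsubstituted ring, a 2.5-fold higher number from compound 1 to compound 4 (0.41 log units; beyond the scatter), adds a second group besides cyano whose difference from hydrogen lies beyond the scatter, whereas the step from hydrogen to methyl stays within it. Nothing measured here accounts for how these groups fall in relation to one another.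

The compounds shown leave open how other groups on this carbon, such as a methoxy group, an amine or a carboxylic acid, would read in this assay, and whether any of them would move the number further from hydrogen than cyano does. Going by these compounds alone, they also leave open whether trifluoromethyl would give a similar number on another carbon of the ring, or whether these steps would carry over to a core other than the one shared by compounds 1 to 4.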